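The compounds below may be only part of what the source reports. "The series", "measured", "known", "first", "only" and "open" are said of these compounds alone.

Working notes on the series. Compound 1 `ClCc1cccc(Cn2cnc3c(Cl)ncnc32)c1` gives 3540 nM in a functional assay on K562 cells (Homo sapiens) for cytotoxicity, read by sulforhodamine B assay, with a stated time of 48 h; on this read-out lower numbers stand for stronger inhibition of growth and higher numbers for weaker inhibition of growth; compound 3 `Nc1nc(Cl)c2ncn(Cc3cccc(CCl)c3)c2n1` gives 4360 nM, the step of a 1.2-fold higher number from compound 1 to compound 3 (0.09 log units; within the scatter) showing that an added amino group leaves the number essentially where it was. Compound 2 `ClCc1ccc(Cn2cnc3nc(Cl)nc(Cl)c32)cc1` gives 3310 nM, within the scatter of both compound 1 and compound 3. Compound 4 `ClCc1ccc(Cn2cnc3ncnc(Cl)c32)cc1` differs from compound 2 by hydrogen in place of chloro on an aromatic carbon. Within the data shown here, no measured step covers the loss of a chloro group on the shared core; the only one-place step available, from compound 1 to compound 3, stayed within the scatter. On that basis no step beyond the scatter is expected, a 1.1-fold higher number from compound 2 to compound 4 (0.02 log units; within the scatter). Compound 4 is therefore estimated at 3500 nM, with a range of 1500 nM to 8000 nM.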

Compound 4, concentration for 50% growth inhibition: 3010 nM
For compound 4 the middle estimate is 1.2-fold (0.07 log units) above the measured one; the range from low to high includes it.
By their numbers in this assay, from the lowest: compounds 4, 2, 1 and 3 (each within the scatter of the next).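

In this assay the step of a 1.1-fold lower number from compound 2 to compound 4 (0.04 log units; within the scatter) shows that chloro on the carbon between two ring nitrogen atoms can give way to hydrogen without leaving the scatter. Together with the earlier amino step at the same carbon, in the series of compound 1 and compound 3, this means that no change at this carbon has yet moved the number beyond the scatter. No evidence bearing on this result is available. From the compounds shown here alone, a methoxy group, a carboxylic acid or a longer chain at this carbon remains open. So does the loss of the other chloro group, which compound 2 and compound 4 share.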